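The source may hold more compounds than are shown below. What is called first, only, known or untested is meant among the compounds shown, and "the series" means these compounds.

Measured so far:
compound 1 `CC(C)OC(=O)NCCS(=O)(=O)NC(=O)c1ccc(Nc2nc(NC3(c4ccc(Cl)cc4)CC3)nc(OCC(F)(F)F)n2)cc1` — 73%
compound 2 `O=C(NS(=O)(=O)CCNCc1ccccc1)c1ccc(Nc2nc(NC3(c4ccc(Cl)cc4)CC3)nc(OCC(F)(F)F)n2)cc1` — 100%

In an ADME assay on microsomes from liver (Rattus norvegicus) for metabolic stability, with a stated time of 10 min (on this read-out lower numbers stand for a less stable compound and higher numbers for a more stable compound), compound 2 stands highest of the two numbers, and the step of a number 27 percentage points higher from compound 1 to compound 2 (beyond the scatter) lies beyond the scatter. Compound 3 `Cc1ccccc1S(=O)(=O)NC(=O)c1ccc(Nc2nc(NC3(c4ccc(Cl)cc4)CC3)nc(OCC(F)(F)F)n2)cc1` differs from compound 2 by 2-methylphenyl in place of 2-(benzylamino)ethyl on a sulfonyl sulfur. Among the compounds with values here, only one measured step exists, and it changed the amine nitrogen rather than the sulfonyl sulfur, so it bears only loosely on this change. The expected step is therefore uncertain, with a modest downward lean, a number 20 percentage points lower from compound 2 to compound 3 (beyond the scatter). Compound 3 is estimated at 80%, within 50% to 100%.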

Compound 3, percent of the compound remaining: 100%
For compound 3 the middle estimate is 20 percentage points below the measured one; the measured number falls inside the stated range.
By their numbers in this assay, from the lowest: compound 1; then compounds 2 and 3 (each within the scatter of the next).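

In this assay, the sulfonyl sulfur accepts 2-methylphenyl as well as 2-(benzylamino)ethyl, with no change at the digits printed from compound 2 to compound 3 (within the scatter). The amine nitrogen in the chain is therefore not required for this read-out, and swapping 2-((isopropoxycarbonyl)amino)ethyl for 2-methylphenyl gives a number 27 percentage points higher from compound 1 to compound 3 (beyond the scatter). Nothing available explains these numbers. Still open, as far as these compounds go, is how a carboxylic acid or a longer alkyl chain on the sulfonyl sulfur would read, and whether a simple methyl would serve as well as the aromatic ring.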